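A few compounds are considered here, and "the series" means these few. Any claim that something is new, unique, unknown or untested is made for them only; others in the source may bear on it.

Of the compounds shown here, two built on a shared core have been tested in a functional assay on HEK293 cells for positive allosteric modulation of metabotropic glutamate receptor 5 (Homo sapiens), read by calcium flux; a lower number here means a smaller maximal response, a higher number a larger maximal response. Compound 1 `O=C(c1ccc(F)cc1)N1CCc2nc(COc3ccncc3)oc2C1` gives 71% in this assay. Compound 2 `O=C(c1cccc(F)c1)N1CCc2nc(COc3cccc(F)c3)oc2C1` gives 75% in this assay. Compound 2 holds the higher of the two numbers, yet its gap to compound 1 lies within the usual scatter of repeated measurements, so the two values cannot be told apart; of this pair only that much can be said, since the two structures differ in more than one place. Compound 3 `O=C(c1c(F)cccc1F)N1CCc2nc(COc3cccc(F)c3)oc2C1` has not yet been measured in this assay. It differs from compound 2 in a single place: 2,6-difluorophenyl in place of 3-fluorophenyl on a carbonyl carbon. Among the measured compounds shown here, no measured pair of compounds that differ in one place exists here, so there is no measured step to lean on for this change, and the ring on the carbonyl carbon has not been varied among the measured compounds. The step from compound 2 to compound 3 is expected to be small, a number 3 percentage points lower from compound 2 to compound 3 (within the scatter), and not beyond the scatter in either direction. Compound 3 is therefore estimated to give about 72%, within a range from 52% to 92%.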

Compound 3, largest response reached (reported as percent of maximum), in percent of the reference or control that the assay uses: 82%
The estimate for compound 3 lay 10 percentage points below the measured number; measured number inside the range.
By their numbers in this assay, from the lowest: compounds 1, 2 and 3 (each within the scatter of the next, the first and the last beyond it).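

The ring on the carbonyl carbon has now been changed with the rest of the molecule held fixed, and in this assay replacing 3-fluorophenyl with 2,6-difluorophenyl gives a number 7 percentage points higher from compound 2 to compound 3 (within the scatter). The two values cannot be told apart, so at this place a phenyl ring carrying two fluorines keeps the maximal response as well as a phenyl ring carrying one, at least on this version of the shared core. No separate data are at hand that would explain this result.

All the rings on the carbonyl carbon shown so far are fluorinated phenyl rings, so it remains open whether an unsubstituted phenyl, a chlorophenyl, a methoxyphenyl or a saturated ring such as cyclohexyl would hold the response in this assay. On these data alone, this single step also comes from one background, and whether the same exchange would give a similar result with the ring found on the other side of the core in compound 1 remains unknown.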